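A few compounds are considered here, and "the series" means these few. Any claim that something is new, unique, unknown or untested is made for them only; others in the source may bear on it.

Measured in an assay on microsomes for inhibition of Amine oxidase [flavin-containing] B (Homo sapiens), read by fluorescence and spectrophotometry, with a stated time of 20 min; on this read-out lower numbers stand for stronger inhibition and higher numbers for weaker inhibition:
- compound 1 `Cn1c(=O)c2c(nc([S+]([O-])CCc3ccc(Cl)cc3)n2C)n(C)c1=O`, compound 1 gives 781 nM
- compound 2 `Cn1c(=O)c2c(nc([S+]([O-])CCc3ccc(Br)cc3)n2C)n(C)c1=O`, compound 2 gives 471 nM

Among the measured compounds shown here, compound 2 is one of two measured members; the only neighbour, compound 1, is separated from it by a 1.7-fold lower number from compound 1 to compound 2 (0.22 log units; within the scatter), so the two numbers are not distinguishable on this read-out.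

Compound 3 `Cn1c(=O)c2c(nc([S+]([O-])CCc3ccc(F)cc3)n2C)n(C)c1=O` is the next member. It differs from compound 2 in one place: fluoro in place of bromo on an aromatic carbon. For the measured compounds named here, the only measured step that bears on an exchange at this position is the one from compound 1 to compound 2, a 1.7-fold lower number from compound 1 to compound 2 (0.22 log units; within the scatter), which did not leave the scatter. On that basis a small step in this assay is expected for compound 3 as well, with a slight lean toward a higher number, but nothing that can be claimed as a clear change. The expected step is a 1.9-fold higher number from compound 2 to compound 3 (0.28 log units; within the scatter). Compound 3 is estimated at 900 nM, with a range from 350 nM to 2500 nM.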

Compound 3, half-maximal inhibitory concentration: 3500 nM
For compound 3 the middle estimate is 3.9-fold (0.59 log units) below the measured one; measured number outside the range, above it.
By their numbers in this assay, from the lowest: compounds 2 and 1 (each within the scatter of the next); then compound 3.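

In this assay the halogen on the aromatic carbon, para to a large group, proves not to be freely exchangeable: a 7.4-fold higher number from compound 2 to compound 3 (0.87 log units; beyond the scatter) and a 4.5-fold higher number from compound 1 to compound 3 (0.65 log units; beyond the scatter) both lie beyond the scatter, whereas the exchange of chloro for bromo did not leave it. Fluoro therefore stands apart from chloro and bromo at this position, and those two remain indistinguishable from each other. No measurement at hand accounts for this separation.

The compounds shown carry only halogens here, so it remains open how a methyl group, a methoxy group or a nitrile at this position would read, and where the plain phenyl would fall relative to compound 3. Also open, on these data alone, is whether the same separation of fluoro holds with a longer chain attached to the shared core.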